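Swapping a short chain for a second pentylphenyl arm

The source may hold more compounds than are shown below. What is called first, only, known or untested is meant among the compounds shown, and "the series" means these compounds.

Compound 2 `CCCCCc1ccc(-c2oc3nc(=O)n([C@H]4C[C@H](OC(C)=O)[C@@H](COC(C)=O)O4)cc3c2C#CCCO)cc1` gives 100000 nM in an ADME assay on HEL cells (Homo sapiens) for cytotoxicity, read by cell counting, with a stated time of 3 days (a higher number here means that more compound is tolerated, a lower number that less compound is tolerated), the highest of the two numbers at hand, while compound 1 `CCCCCc1ccc(C#Cc2c(-c3ccc(C)cc3)oc3nc(=O)n([C@H]4C[C@H](OC(C)=O)[C@@H](COC(C)=O)O4)cc23)cc1` gives 20000 nM. Compound 3 `CCCCCc1ccc(C#Cc2c(-c3ccc(CCCCC)cc3)oc3nc(=O)n([C@H]4C[C@H](OC(C)=O)[C@@H](COC(C)=O)O4)cc23)cc1` differs from compound 2 by 4-pentylphenyl in place of 2-hydroxyethyl on a triple-bonded carbon. That change makes compound 3 resemble compound 1, which is tolerated less well, so a downward step beyond the scatter is expected, estimated as a 6.7-fold lower number from compound 2 to compound 3 (0.82 log units; beyond the scatter). In this assay compound 3 is therefore expected to give about 15000 nM, plausibly between 5000 nM and 50000 nM.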

Compound 3, minimum cytotoxic concentration: 100000 nM
Estimate against measurement, compound 3: 6.7-fold (0.82 log units) below; the whole stated range lies below it.
By their numbers in this assay, from the lowest: compound 1; then compounds 2 and 3 (each within the scatter of the next).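

In this assay, 4-pentylphenyl in place of 2-hydroxyethyl on a triple-bonded carbon gives no change at the digits printed from compound 2 to compound 3 (within the scatter), so this position accepts the much larger arm with no loss of tolerance. Butyl in place of hydrogen on a saturated chain carbon bound to an aromatic carbon gives a 5.0-fold higher number from compound 1 to compound 3 (0.70 log units; beyond the scatter), so the lower number of compound 1 goes with the absent butyl, not with the arm itself. Nothing measured here explains either result. Still open, on these data alone, is whether an amine or a carboxylic acid in place of 2-hydroxyethyl on a triple-bonded carbon would be tolerated equally well.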